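The compounds below may be only part of what the source reports. "The series", "measured", "known", "first", "only" and "open" are said of these compounds alone.

Working notes on the series. In a physicochemical assay for lipophilicity, at pH 7.4 (on this read-out lower numbers stand for lower lipophilicity and higher numbers for higher lipophilicity), compound 1 (`CNS(=O)(=O)c1ccc(-c2cnc(N)c(-c3ccc(OC)nc3)c2)cc1`) gives 2.2 and compound 2 (`COc1ccc(-c2cc(-c3ccc(S(C)(=O)=O)c(F)c3)cnc2N)cn1`) gives 2.5 on the same scale. For the measured compounds named here, these two values lie within the usual scatter of each other, so compound 1 stands level with compound 2 on the only two numbers available. Compound 3 (`COc1ccc(-c2cc(-c3ccc(C(F)(F)F)cc3)cnc2N)cn1`) has not yet been measured. Its structural change from compound 1 is trifluoromethyl in place of methylsulfamoyl on an aromatic carbon and amounts to trifluoromethyl in place of methylsulfamoyl on an aromatic carbon, para to a large group. Going by the values given here, no two measured compounds differ in one place only, so the expectation rests on this change alone. The expected step, upward in this assay and well beyond the scatter, is a number 1.70 log units higher from compound 1 to compound 3 (beyond the scatter) as estimated here. For compound 3 the estimated value is 3.9 with an expected range from 3.3 to 4.5 for a single measurement.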

Compound 3, distribution coefficient: 4.2
Estimate against measurement, compound 3: 0.30 log units below; low and high end bracket the measured number.
By their numbers in this assay, from the lowest: compounds 1 and 2 (each within the scatter of the next); then compound 3.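

In this assay, for the compounds shown here, trifluoromethyl in place of methylsulfamoyl on an aromatic carbon, para to a large group, gives a number 2.00 log units higher from compound 1 to compound 3 (beyond the scatter), the only step between compounds that differ in one place, and it shows that the read-out responds strongly to the group at this position. The exchange replaces a group carrying a hydrogen-bond donor and hydrogen-bond acceptors with one carrying neither, but a single pair cannot show which difference between the two groups accounts for the size of the step. No measurement available here bears on the reason for the step.

The compounds shown leave open where an amine, a carboxylic acid or a longer alkyl chain on the same carbon would fall on this scale. They also leave open whether the same exchange gives a step of similar size on a different core.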